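A few compounds are considered here, and "the series" means these few. Any claim that something is new, unique, unknown or untested is made for them only; others in the source may bear on it.

Compound 1, `N=C(N)NCCC[C@H](NC(=O)c1ccccc1)C(=O)N(CCCCN)CC(=O)N[C@@H](C(N)=O)c1ccccc1`: 10.6%
Compound 2, `N=C(N)NCCCN(CC(=O)N[C@@H](CCCCN)C(=O)N[C@@H](C(N)=O)c1ccccc1)C(=O)c1ccccc1`: <= 5%
Compound 3, `N=C(N)NCCC[C@H](NC(=O)c1ccccc1)C(=O)N[C@@H](CCCCN)CC(=O)N(CC(N)=O)c1ccccc1`: <= 5%

These three compounds were tested in an assay on isolated protein for inhibition of Trypsin (Homo sapiens), read by fluorescence, with a stated time of 15 min, tested at 50 uM; on this read-out lower numbers stand for less inhibition and higher numbers for more inhibition at the one concentration tested (going by the name of the read-out). Compound 1 gives 10.6%, a weak read-out at the single concentration used. Compound 2 gives <= 5%, which is a limit of the assay and not a measured number. Compound 3 likewise gives <= 5%, again a limit rather than a number. Compound 3 therefore stands at the floor of what the assay reports, and it shares that floor with compound 2 (the limit of <= 5% in this assay, at which 2 of the 3 values shown sit). Among the compounds with values here, the three measured compounds are built from the same atoms joined differently, but no pair of them differs in only one place, so no single change among them can be followed directly.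

Compound 4 `N=C(N)NCCC[C@H](NC(=O)c1ccccc1)C(=O)N[C@@H](CCCCN)CC(=O)N[C@@H](C(N)=O)c1ccccc1` has not yet been measured. It differs from compound 3 in one place (carbamoyl(phenyl)methyl)amino in place of (carbamoylmethyl)(phenyl)amino on a carbonyl carbon: the group sits on a carbonyl carbon whose other neighbour is a saturated chain carbon. Within the data shown here, since no measured step is available to lean on, the step from compound 3 is expected to be small, and not beyond the scatter of this assay (a number at least 3 percentage points higher from compound 3 to compound 4 (that floor lies within the scatter)). Compound 4 is estimated to give 8%, within a range from 3% to 16%.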

Compound 4, a percentage reported as inhibition, at one concentration (the size of the read-out at that concentration, not a potency): <= 5%
Compound 4: no number, only a limit; the forecaster's own chance of this, stated with the estimate: 40%; at least 3 percentage points between middle value and limit.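

Compound 4 gives <= 5%, which is a limit of the assay and not a number. Compound 3 also has only a limit in this assay, so no step between compound 3 and compound 4 can be read: the limit of <= 5% in this assay, at which 3 of the 4 values shown sit.

The compounds shown leave open whether (carbamoyl(phenyl)methyl)amino in place of (carbamoylmethyl)(phenyl)amino changes inhibition at all.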